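Positional isomer of a trifluoromethylphenyl group: expected effect

A few compounds are considered here, and "the series" means these few. Any claim that something is new, unique, unknown or untested is made for them only; others in the source may bear on it.

Measured so far:
compound 1 `CN(C(=O)NC(=O)c1cccc(C(F)(F)F)c1)c1nc(C(F)(F)F)c(C(=O)N/N=C/c2ccc(C(F)(F)F)cc2)s1`: 6.5 ug/mL
compound 2 `CN(C(=O)NC(=O)c1ccccc1F)c1nc(C(F)(F)F)c(C(=O)N/N=C/c2cccc(C(F)(F)F)c2)s1`: 20.5 ug/mL

In a functional assay on MCF7 cells (Homo sapiens) for inhibition, read by MTT assay, with a stated time of 72 h (on this read-out higher numbers stand for weaker inhibition and lower numbers for stronger inhibition), compound 1 gives 6.5 ug/mL and compound 2 gives 20.5 ug/mL; compound 2 carries the higher of the two numbers, and its gap to compound 1 lies beyond the scatter. Compound 3 `CN(C(=O)NC(=O)c1ccccc1F)c1nc(C(F)(F)F)c(C(=O)N/N=C/c2ccc(C(F)(F)F)cc2)s1` is compound 2 with 4-(trifluoromethyl)phenyl in place of 3-(trifluoromethyl)phenyl on a carbon with a double bond to nitrogen. No single-site comparison among the measured compounds isolates this change; compound 1 also carries the 4-(trifluoromethyl)phenyl group but differs from compound 2 at a second place, so its lower number cannot be assigned to this change alone. A modest step toward a lower number is expected for compound 3, a 1.7-fold lower number from compound 2 to compound 3 (0.23 log units; within the scatter). Compound 3 is therefore estimated at 12 ug/mL, within 5 ug/mL to 30 ug/mL.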

Compound 3, half-maximal inhibitory concentration: 4.98 ug/mL
Compound 3: the middle estimate sits 2.4-fold (0.38 log units) above what was measured; the measured number lies below the stated range.
By their numbers in this assay, from the lowest: compounds 3 and 1 (each within the scatter of the next); then compound 2.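

Among the compounds shown here, with the rest of compound 2 unchanged, 4-(trifluoromethyl)phenyl in place of 3-(trifluoromethyl)phenyl on a carbon with a double bond to nitrogen gives a 4.1-fold lower number from compound 2 to compound 3 (0.61 log units; beyond the scatter) in this assay and isolates this isomer change for the first time. With 4-(trifluoromethyl)phenyl held there, 2-fluorophenyl in place of 3-(trifluoromethyl)phenyl on a carbonyl carbon gives a 1.3-fold lower number from compound 1 to compound 3 (0.12 log units; within the scatter) and so shows no separable effect in this assay. Nothing available explains either step.

On these data alone, whether the isomer step holds with 3-(trifluoromethyl)phenyl on the carbonyl carbon remains open. A phenyl ring bearing an amine or a carboxylic acid on the carbon with a double bond to nitrogen also remains untested in the compounds shown.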